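The compounds below may be only part of what the source reports. "The series", "measured", "known", "first", "only" and "open" are said of these compounds alone.

Working notes on the series, all on a shared core. Going by the values given here, compound 2 `Fc1ccccc1Cn1nnc2c(NC3CC3)nc(-c3ccccc3)nc21` gives in an assay on isolated protein for binding affinity to adenosine receptor A1 (Bos taurus) (on this read-out higher numbers stand for weaker inhibition and lower numbers for stronger inhibition), a value of 15000000 nM, the highest of the three numbers measured so far. Compound 3 `Clc1ccccc1Cn1nnc2c(NC3CC3)nc(-c3ccccc3)nc21`, carrying chloro in place of fluoro on an aromatic carbon, gives 11000000 nM; the step of a 1.4-fold lower number from compound 2 to compound 3 (0.13 log units; within the scatter) lies within the scatter, so these two cannot be told apart. Compound 1 `OC1CCC(Nc2nc(-c3ccccc3)nc3c2nnn3Cc2ccccc2F)CC1` gives 1850000 nM, and the step of an 8.1-fold higher number from compound 1 to compound 2 (0.91 log units; beyond the scatter) is the only one in the set that lies beyond the scatter.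

Compound 4 `CCNc1nc(-c2ccccc2)nc2c1nnn2Cc1ccccc1F` has not been measured; it differs from compound 2 in one place: ethyl in place of cyclopropyl on a nitrogen on an aromatic ring. Among the compounds with values here, of the measured steps only the one at the same nitrogen on an aromatic ring bears on this, and that step, an 8.1-fold higher number from compound 1 to compound 2 (0.91 log units; beyond the scatter), is modest although it swaps 4-hydroxycyclohexyl for cyclopropyl. Cyclopropyl to ethyl is a smaller change, and nothing measured separates a three-membered ring from a short chain, so a step not beyond the scatter is expected. Compound 4 is therefore estimated to give 15000000 nM, with a range from 5000000 nM to 45000000 nM. The expected step reads no change at the digits printed from compound 2 to compound 4 (within the scatter).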

Compound 4, inhibition constant: 11000000 nM
Estimate against measurement, compound 4: 1.4-fold (0.13 log units) above; low and high end bracket the measured number.
By their numbers in this assay, from the lowest: compound 1; then compounds 3, 4 and 2 (each within the scatter of the next).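

At the nitrogen on an aromatic ring, ethyl in place of cyclopropyl gives in this assay a step within the scatter (a 1.4-fold lower number from compound 2 to compound 4 (0.13 log units; within the scatter)), so the three-membered ring is not separated from a short chain at this position. A second small group now stands against 4-hydroxycyclohexyl (a 5.9-fold higher number from compound 1 to compound 4 (0.77 log units; beyond the scatter)), and like compound 2 (an 8.1-fold higher number from compound 1 to compound 2 (0.91 log units; beyond the scatter)) it lies beyond the scatter from compound 1, so the gap no longer rests on cyclopropyl alone. No independent data explain either step.

The compounds shown leave open whether the lower number of compound 1 belongs to the cyclohexyl ring or to its hydroxyl, which unsubstituted cyclohexyl and 2-hydroxyethyl on the same nitrogen would separate. Also open, from the compounds shown here alone, is how a longer chain such as butyl would read at this nitrogen.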